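Swapping 4-methoxyphenyl for 3-chlorophenyl: notes on compound 3

The source may hold more compounds than are shown below. What is called first, only, known or untested is meant among the compounds shown, and "the series" means these compounds.

In a functional assay on HuTu80 cells (Homo sapiens) for cytotoxicity, read by MTT assay, with a stated time of 72 h (on this read-out higher numbers stand for an effect only at larger amounts of compound and lower numbers for an effect already at smaller amounts), compound 1 `O=C1/C(=C\c2ccc(F)cc2)c2ccccc2N1c1c(Cl)cccc1Cl` gives 8 ug/mL.

Compound 2 `COc1ccc(/C=C2\C(=O)N(c3c(Cl)cccc3Cl)c3ccccc32)cc1` gives > 100 ug/mL, which is a limit of the assay and not a number.

Compound 3 `O=C1/C(=C\c2cccc(Cl)c2)c2ccccc2N1c1c(Cl)cccc1Cl` has 3-chlorophenyl in place of 4-methoxyphenyl on a double-bonded chain carbon bound to a double-bonded ring carbon.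

Going by the values given here, only one measured step bears on this change: an at least 12-fold higher number from compound 1 to compound 2 (1.09 log units; beyond the scatter). It is large and beyond the scatter, and it comes from methoxy in place of fluoro on an aromatic carbon. Compound 3 also lacks the methoxy and carries a halogen, as compound 1 does. Among the compounds with values here, the parallel is only partial, since the halogen is chloro rather than fluoro, no measured compound carries 3-chlorophenyl, and the evidence rests on a single pair.

A large move back towards a lower number in this assay is therefore expected, beyond the scatter. The expected change is an at least 6.6-fold lower number from compound 2 to compound 3 (0.82 log units; beyond the scatter).

For compound 3 the estimated value is 15 ug/mL, with an expected range of 4 ug/mL to 70 ug/mL.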

Compound 3, concentration for half-maximal effect: 7 ug/mL
Beside the measured number, compound 3's estimate is 2.1-fold (0.33 log units) above it; the measured number falls inside the stated range.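

In this assay, 3-chlorophenyl in place of 4-methoxyphenyl on a double-bonded chain carbon bound to a double-bonded ring carbon gives an at least 14-fold lower number from compound 2 to compound 3 (1.15 log units; beyond the scatter), so this position now has a second replacement for 4-methoxyphenyl that gives a large step, and not only 4-fluorophenyl. Against 4-fluorophenyl at the same place, 3-chlorophenyl gives a 1.1-fold lower number from compound 1 to compound 3 (0.06 log units; within the scatter), so this assay does not separate these two halogen-bearing groups, and among the three compounds only the one with 4-methoxyphenyl stands apart. The true size of the step from the methoxy compound remains unknown, as compound 2 gives a limit and not a number: the limit of > 100 ug/mL in this assay, at which 1 of the 3 values shown sits.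

The compounds shown do not tell whether the low numbers call for a halogen on the phenyl ring or only for the absence of methoxy, and an unsubstituted phenyl at this place would bear directly on that question. Nor do they show how this position responds to a phenyl ring carrying an amine or a carboxylic acid, and 3-chlorophenyl and 4-fluorophenyl differ in both the halogen and its place on the ring, so those two factors cannot be separated here.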